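This account rests on a few compounds, and the source may have more. Where it says the series, first, only, none or still open, it means among the compounds named here.

Compound 1 `C=CC(=O)Nc1cccc(NC(=O)CSc2nc(Nc3ccccc3)c3ccccc3n2)c1` gives 10200 nM in a functional assay on MDA-MB-231 cells (Homo sapiens) for inhibition, read by MTT assay, with a stated time of 72 h; a lower number here means a stronger inhibitor, a higher number a weaker inhibitor. Within the data shown here, compound 2 `C=CC(=O)Nc1cccc(NC(=O)CSc2nc(Nc3ccccc3Cl)c3ccccc3n2)c1` gives 12700 nM in this assay; it stands with compound 1 inside the scatter, the only measured step being a 1.2-fold higher number from compound 1 to compound 2 (0.10 log units; within the scatter). Compound 3 `C=CC(=O)Nc1cccc(NC(=O)CSc2nc(Nc3ccccc3Br)c3ccccc3n2)c1` carries the change (bromo in place of chloro on an aromatic carbon). Among the measured compounds shown here, no measured step exchanges one halogen for another; the single known step, chloro for hydrogen at this place, stayed within the scatter. The expected step is therefore a 1.1-fold lower number from compound 2 to compound 3 (0.02 log units; within the scatter), not beyond the scatter. Compound 3 is estimated at 12000 nM, with a range from 6000 nM to 25000 nM.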

Compound 3, half-maximal inhibitory concentration: 15200 nM
Compound 3: middle estimate off by 1.3-fold (0.10 log units), on the low side; low and high end bracket the measured number.
By their numbers in this assay, from the lowest: compounds 1, 2 and 3 (each within the scatter of the next).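

Bromo in place of chloro on an aromatic carbon ortho to a large group gives the series its first halogen exchange: in this assay, a 1.2-fold higher number from compound 2 to compound 3 (0.08 log units; within the scatter). Bromo in place of hydrogen at this place also stays inside the scatter, a 1.5-fold higher number from compound 1 to compound 3 (0.17 log units; within the scatter), so hydrogen, chloro and bromo here cannot be told apart in this read-out. Nothing available bears on why these three compounds read alike.

Open, going by these compounds, is whether a non-halogen group at this place, such as methoxy, an amine or a carboxylic acid, would give a step beyond the scatter. Also open, on these data alone, is whether halogens on other carbons of this ring would do so.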